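A Cyclopropyl Added to the Phenyl of Compound 2

The compounds below may be only part of what the source reports. "The series", "measured", "known", "first", "only" and "open" are said of these compounds alone.

Compound 2 `COc1ncc(C(F)(F)F)cc1CO[C@H]1[C@H](C(C)(C)C)[C@@H](C(=O)O)N(C(=O)[C@@H]2CCCCO2)[C@H]1c1ccccc1` gives the largest response of the three compounds measured in an assay on cells with Cystic fibrosis transmembrane conductance regulator variant F508del (Homo sapiens) as the target, read by voltage clamp, with a stated time of 24 h, in the presence of a further agent that is not named here; a lower number here means a smaller maximal response, a higher number a larger maximal response: compound 2 reaches 720%, compound 1 `COc1ncc(C(F)(F)F)cc1CO[C@H]1[C@H](C(C)(C)C)[C@@H](C(=O)O)N(C(=O)OC(C)C)[C@H]1c1ccccc1` reaches 438%, and compound 3 `COc1ncc(C(F)(F)F)cc1CO[C@H]1[C@H](C(C)(C)C)[C@@H](C(=O)O)N(C(=O)[C@H]2CCCCO2)[C@H]1c1ccccc1` reaches 351%. All three steps are large: a number 282 percentage points higher from compound 1 to compound 2 (beyond the scatter), a number 87 percentage points lower from compound 1 to compound 3 (beyond the scatter) and a number 369 percentage points lower from compound 2 to compound 3 (beyond the scatter), the last one between two compounds that share every atom and bond and differ only in configuration as drawn (the fact that compounds 2 and 3 differ only in the configuration as drawn). Compound 4 `COc1ncc(C(F)(F)F)cc1CO[C@H]1[C@H](C(C)(C)C)[C@@H](C(=O)O)N(C(=O)[C@@H]2CCCCO2)[C@H]1c1ccccc1C1CC1` differs from compound 2 by cyclopropyl in place of hydrogen on an aromatic carbon. Going by the values given here, none of the measured steps touches the phenyl, so none of them bears on this change, and no direction can be drawn from them. The expected step is therefore no change at the digits printed from compound 2 to compound 4 (within the scatter). Compound 4 is expected to give 720%, with a range from 400% to 1000%.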

Compound 4, largest response reached (Emax), in percent of the reference or control that the assay uses: 610%
Compound 4: middle estimate off by 110 percentage points, on the high side; measured number inside the range.
By their numbers in this assay, from the lowest: compound 3; then compound 1; then compound 4; then compound 2.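

The phenyl is a position that responds to change: cyclopropyl in place of hydrogen on an aromatic carbon, ortho to a large group, gives a number 110 percentage points lower from compound 2 to compound 4 (beyond the scatter). The maximal response falls but does not vanish, since compound 4 still reaches 610%. Nothing measured here explains why this step goes down. On these data alone, whether a methyl, a methoxy or an amine in the same place would also lower the response remains open. So does the effect of cyclopropyl on compound 3, the partner of compound 2 with one stereocentre reversed.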